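The source may hold more compounds than are shown below. What is called first, only, known or untested is meant among the compounds shown, and "the series" means these compounds.

Measured in a functional assay on PC-3 cells (Homo sapiens) for inhibition, read by sulforhodamine B assay, with a stated time of 48 h; a lower number here means a stronger inhibitor of growth, a higher number a weaker inhibitor of growth:
- compound 1 `Cc1ccc(NC(=S)N/N=C/c2cccs2)cc1`: 29700 nM
- compound 2 `CCc1ccc(NC(=S)N/N=C/c2cccs2)cc1`: > 100000 nM (a limit)

Compound 2 gives > 100000 nM, which is a limit of the assay and not a number. Its standing rests only on (the limit of > 100000 nM in this assay, at which 1 of the 2 values shown sits).

Compound 3 `S=C(N/N=C/c1cccs1)Nc1ccc(Br)cc1` has bromo in place of ethyl on an aromatic carbon.

Among the compounds with values here, one measured step bears on this, though it does not test bromo directly: an at least 3.3-fold higher number from compound 1 to compound 2 (0.52 log units; beyond the scatter), which lies beyond the scatter. That step built the ethyl of compound 2 from a methyl at the same place, and the change to compound 3 removes the ethyl. A lower number is therefore expected in this assay, with compound 1 at 29700 nM as the closest guide. The expected change is an at least 2.8-fold lower number from compound 2 to compound 3 (0.45 log units; beyond the scatter), of about the size of the measured step, although another limit reading remains possible. For compound 3 the estimated value is 35000 nM, with an expected range of 12000 nM to 100000 nM.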

Compound 3, concentration for 50% growth inhibition: 79400 nM
Compound 3: middle estimate off by 2.3-fold (0.36 log units), on the low side; the measured number falls inside the stated range.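

In this assay, putting bromo where compound 1 carries methyl gives a 2.7-fold higher number from compound 1 to compound 3 (0.43 log units; beyond the scatter), so the move away from methyl at this position weakens growth inhibition with a halogen as well as with ethyl, and compound 1 stands as the strongest of the three. Bromo in place of ethyl gives an at least 1.2-fold lower number from compound 2 to compound 3 (0.10 log units; that floor lies within the scatter), a floor that allows no order to be read between these two compounds. The reading for compound 2 is a limit of the assay and not a number: the limit of > 100000 nM in this assay, at which 1 of the 3 values shown sits.

The compounds shown leave open how hydrogen, fluoro, methoxy or an amine at this place compares with methyl. It therefore remains unclear whether methyl itself favours growth inhibition in the shared core or whether ethyl and bromo each disfavour it.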